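Moving the Bromine on the Amide Nitrogen Aryl Group

This account rests on a few compounds, and the source may have more. Where it says the series, first, only, none or still open, it means among the compounds named here.

Measured so far:
compound 1 `CN(C)C(=O)c1cc2cnc(Nc3ccc(NC(=O)C4(C(=O)Nc5ccc(F)cc5)CC4)cc3F)nc2n1C1CCCC1` — 33%
compound 2 `CN(C)C(=O)c1cc2cnc(Nc3ccc(NC(=O)C4(C(=O)Nc5ccc(Br)cc5)CC4)cc3)nc2n1C1CCCC1` — 87.8%
compound 3 `CN(C)C(=O)c1cc2cnc(Nc3ccc(NC(=O)C4(C(=O)Nc5cccc(Cl)c5)CC4)cc3)nc2n1C1CCCC1` — 88.1%

All three numbers come from a functional assay on OVCAR-5 cells (Homo sapiens) for inhibition, read by CCK-8 assay, with a stated time of 72 h, tested at 10 uM; on this read-out lower numbers stand for less inhibition of growth and higher numbers for more inhibition of growth at the one concentration tested. Compound 2 stands second highest of the three. Its nearest neighbour is compound 3, where a number 0.3 percentage points higher from compound 2 to compound 3 (within the scatter) lies within the scatter, so the two cannot be told apart on these numbers. Within the data shown here, compound 1 is the furthest away, and its value sits far below that of compound 2; no single-point step links those two, as compound 1 also carries a fluorine on the central ring.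

Compound 4 `CN(C)C(=O)c1cc2cnc(Nc3ccc(NC(=O)C4(C(=O)Nc5cccc(Br)c5)CC4)cc3)nc2n1C1CCCC1` is the next candidate. It differs from compound 2 by 3-bromophenyl in place of 4-bromophenyl on an amide-type nitrogen. Among the measured compounds shown here, the one measured step that speaks to this is the move from compound 2 to compound 3, in which the halogen on the same aryl group was exchanged and relocated, and which gave a number 0.3 percentage points higher from compound 2 to compound 3 (within the scatter). On that basis compound 4 is expected to show a number 0.8 percentage points lower from compound 2 to compound 4 (within the scatter), no movement beyond the scatter. Compound 4 is therefore estimated at 87%, with a range from 74% to 95%.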

Compound 4, percent growth inhibition at one concentration: 89.6%
The estimate for compound 4 lay 2.6 percentage points below the measured number, and the stated range covers the measured number.
By their numbers in this assay, from the lowest: compound 1; then compounds 2, 3 and 4 (each within the scatter of the next).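

In this assay, moving the bromine alone, with 3-bromophenyl in place of 4-bromophenyl on the amide-type nitrogen, gives a number 1.8 percentage points higher from compound 2 to compound 4 (within the scatter) and so separates the relocation from the halogen exchange that were combined in the earlier step. Exchanging the halogen alone, with bromo in place of chloro on an aromatic carbon, gives a number 1.5 percentage points higher from compound 3 to compound 4 (within the scatter) and so completes the set of single changes among these three compounds. Neither change can be told apart from no change on this read-out, and nothing at hand bears on the reason for this result.

The compounds shown leave open whether an amine, a carboxylic acid or a methoxy group on this aryl ring would give a similar number. They also leave open how much of the low number of compound 1 belongs to its fluorine on the central ring and how much to its 4-fluorophenyl group.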